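A few compounds are considered here, and "the series" means these few. Any claim that something is new, unique, unknown or untested is made for them only; others in the source may bear on it.

Of the compounds shown here, two have been measured so far. In an in vivo ADME assay on the whole organism for metabolic stability, with Rattus norvegicus as the target, at a dose of 1 mg/kg by the intravenous route (a lower number here means that the compound disappears faster, a higher number that the compound lasts longer), compound 1 `O=C(NOC[C@H](O)CO)c1ccc2cnsc2c1Nc1ccc(I)cc1F` gives 1.6 h and compound 2 `O=C(NOCCO)c1ccc2[nH]ncc2c1Nc1ccc(I)cc1F` gives 1.4 h. These two numbers lie within the usual scatter of repeated measurements, so compound 2 stands level with compound 1 on the data so far.

The next compound, compound 3 `O=C(NOCCO)c1ccc2[nH]ncc2c1Nc1ccc(Br)cc1F`, changes compound 2 in one place: bromo in place of iodo on an aromatic carbon. In words, bromo takes the place of iodo on an aromatic carbon, turning 2-fluoro-4-iodophenyl into 4-bromo-2-fluorophenyl. Among the measured compounds shown here, compounds 1 and 2 both carry the iodo group, so no measured pair shows what this swap does to this assay. With no such evidence, no step beyond the scatter is expected in either direction. The expected change is small, no change at the digits printed from compound 2 to compound 3 (within the scatter). For compound 3 the estimated half-life is 1.4 h, with an expected range of 0.7 h to 2.7 h.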

Compound 3, half-life: 0.36 h
Compound 3: middle estimate off by 3.9-fold (0.59 log units), on the high side, outside the stated range (below it).
By their numbers in this assay, from the lowest: compound 3; then compounds 2 and 1 (each within the scatter of the next).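

This position is not a silent one. In this assay bromo in place of iodo brings a 3.9-fold lower number from compound 2 to compound 3 (0.59 log units; beyond the scatter), although one heavy atom simply replaces another, with no change in rings, hydrogen-bond donors, hydrogen-bond acceptors or net charge. Compounds 1 and 2 both carry iodo and could not reveal this sensitivity, and no measurement shown here explains why the step occurs.

This single pair leaves open whether the same swap would give a similar step on the core of compound 1, with its different side chain. It also leaves open where other groups at this position, such as chloro, methyl or a nitrile, would fall relative to iodo and bromo, and so whether the half-life follows any order across such groups.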